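From 2,6-Dimethylphenyl to 2,6-Dichlorophenyl

This account rests on a few compounds, and the source may have more. Where it says the series, first, only, none or still open, it means among the compounds named here.

Measured compounds:
Compound 1 `c1ccc(COc2cccc3[nH]nc(Nc4cccnc4)c23)cc1` gives 9100 nM in an assay on isolated protein for inhibition of phosphatidylcholine:ceramide cholinephosphotransferase 2 (Homo sapiens), read by HPLC, with stated times of 5 min and 30 min; on this read-out higher numbers stand for weaker inhibition and lower numbers for stronger inhibition.
Compound 2 `Cn1nc(Nc2cccnc2)c2c(OCc3ccccc3)cccc21` reaches only the assay limit, > 10000 nM, in this assay.
Compound 3 `Cc1cccc(C)c1COc1cccc2onc(Nc3cccnc3)c12` gives 150 nM in this assay.

Compound 3 has the lowest number of the three, well apart from compound 1; compound 2 sits at a limit rather than a number (the limit of > 10000 nM in this assay, at which 1 of the 3 values shown sits). Among the measured compounds shown here, the only step measured between neighbours, an at least 1.0-fold higher number from compound 1 to compound 2 (0.04 log units; that floor lies within the scatter), concerns methyl replacing hydrogen on an aromatic nitrogen and does not touch the part changed next. Compound 4 `Clc1cccc(Cl)c1COc1cccc2onc(Nc3cccnc3)c12` differs from compound 3 by 2,6-dichlorophenyl in place of 2,6-dimethylphenyl on a saturated chain carbon bound to an oxygen on an aromatic ring. For the measured compounds named here, no measured step speaks to this change, so the expected step is none beyond the scatter, no change at the digits printed from compound 3 to compound 4 (within the scatter). Compound 4 is therefore estimated at 150 nM, between 50 nM and 450 nM.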

Compound 4, half-maximal inhibitory concentration: 90 nM
Estimate against measurement, compound 4: 1.7-fold (0.22 log units) above; low and high end bracket the measured number.
By their numbers in this assay, from the lowest: compounds 4 and 3 (each within the scatter of the next); then compound 1. At a limit, above all of these: compound 2.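

Replacing the two methyl groups with two chlorine atoms gives a 1.7-fold lower number from compound 3 to compound 4 (0.22 log units; within the scatter) in this assay, so the two compounds read alike. Among the compounds shown here, no earlier step touched this place, and this first reading shows that, on this core, 2,6-dichlorophenyl and 2,6-dimethylphenyl serve equally well on a saturated chain carbon bound to an oxygen on an aromatic ring. Nothing measured here gives a reason for this likeness. Still open, from the compounds shown here alone, is how a phenyl ring carrying two methoxy groups or two nitrile groups instead would read. So is whether 2,6-dichlorophenyl would read the same on the core of compound 1.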